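The source may hold more compounds than are shown below. What is called first, only, known or untested is meant among the compounds shown, and "the series" means these compounds.

Compound 1 `CC(C)[C@H](C(=O)NC(C)(C)C)c1ccc(Cl)cc1` sits at a limit in a functional assay on CHO cells for agonist activity at Free fatty acid receptor 2 (Homo sapiens), read by cAMP accumulation; a higher number here means a larger maximal response, a lower number a smaller maximal response: < 30% (the limit of < 30% in this assay, at which 1 of the 3 values shown sits).
Compound 2 `CC(C)[C@H](C(=O)Nc1nncs1)c1ccc(Cl)cc1` gives 115%.
Compound 3 `CC(C)[C@H](C(=O)Nc1cnns1)c1ccc(Cl)cc1` gives 48%.

Among the two numbers, compound 3 stands lowest; the exchange of one five-membered heteroaryl for another runs a number 67 percentage points lower from compound 2 to compound 3 (beyond the scatter). Compound 4 `CC(C)[C@H](C(=O)Nc1ncc(C#N)s1)c1ccc(Cl)cc1` carries a further change of this kind: 5-cyano-1,3-thiazol-2-yl in place of 1,2,3-thiadiazol-5-yl on an amide-type nitrogen. For the measured compounds named here, no measured step covers this exact exchange. The two that bear on it are a number 67 percentage points lower from compound 2 to compound 3 (beyond the scatter), which was large, and a number at least 18 percentage points higher from compound 1 to compound 3 (beyond the scatter), which was at least modest. A swap of the heteroaryl on the amide nitrogen has therefore shifted the maximal response by large amounts in both directions, and for compound 4 a step upward beyond the scatter is expected, a number 47 percentage points higher from compound 3 to compound 4 (beyond the scatter). Compound 4 is estimated at 95%, with a range from 55% to 130%.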

Compound 4, largest response reached (reported as efficacy), in percent of the reference or control that the assay uses: 105%
Compound 4: middle estimate off by 10 percentage points, on the low side; measured number inside the range.
By their numbers in this assay, from the lowest: compound 3; then compounds 4 and 2 (each within the scatter of the next). At a limit, below all of these: compound 1.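

Swapping the 1,2,3-thiadiazol-5-yl group for 5-cyano-1,3-thiazol-2-yl gives a number 57 percentage points higher from compound 3 to compound 4 (beyond the scatter), while the exchange with the other thiadiazole gives a number 10 percentage points lower from compound 2 to compound 4 (within the scatter), so a high maximal response on this amide-type nitrogen is not confined to a single ring type among these compounds. Against the tert-butyl amide, whose value is a limit, the change gives a number at least 75 percentage points higher from compound 1 to compound 4 (beyond the scatter), the same direction as both thiadiazoles. Nothing measured here gives a cause for these steps.

The compounds shown leave open what the nitrile contributes, and how a 1,3-thiazol-2-yl ring carrying a methyl group or a carboxylic acid in its place would respond. Potency at this receptor also stays open, as only maximal response is shown.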